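The compounds below may be only part of what the source reports. "The series", "measured", "known", "first", "only" and "open" are said of these compounds alone.

Compound 1 `CC(=O)Nc1ccc(S(=O)(=O)NNc2ccc(C)cc2)cc1` gives 51 nM in an assay for inhibition of Indoleamine 2,3-dioxygenase 1 (Homo sapiens), read by spectrophotometry, with stated times of 1 h and 4 h (on this read-out lower numbers stand for stronger inhibition and higher numbers for weaker inhibition), the lowest of the three numbers measured. Compound 2 `CC(=O)Nc1ccc(S(=O)(=O)NNc2ccc(C#N)cc2)cc1` gives 5670 nM and compound 3 `CC(=O)Nc1ccc(S(=O)(=O)NNc2ccc(S(N)(=O)=O)cc2)cc1` gives 2480 nM. Compound 4 `CC(=O)Nc1ccc(S(=O)(=O)NNc2cccc(Br)c2)cc1` differs from compound 1 by 3-bromophenyl in place of 4-methylphenyl on an amine nitrogen. Within the data shown here, no measured step exchanges a 4-methylphenyl for a 3-bromophenyl; the closest steps replace the methyl of the 4-methylphenyl, a 110-fold higher number from compound 1 to compound 2 (2.05 log units; beyond the scatter) and a 49-fold higher number from compound 1 to compound 3 (1.69 log units; beyond the scatter), both large losses. A bromine is neither a cyano nor a sulfamoyl, so a step of that size is not assured, yet some increase beyond the scatter is expected for compound 4: a 4.9-fold higher number from compound 1 to compound 4 (0.69 log units; beyond the scatter). Compound 4 is therefore estimated at 250 nM, with a range from 50 nM to 1500 nM.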

Compound 4, half-maximal inhibitory concentration: 255 nM
Beside the measured number, compound 4's estimate is 1.0-fold (0.01 log units) below it, and the stated range covers the measured number.
By their numbers in this assay, from the lowest: compound 1; then compound 4; then compound 3; then compound 2.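

In this assay, 3-bromophenyl in place of 4-methylphenyl on the amine nitrogen gives a 5.0-fold higher number from compound 1 to compound 4 (0.70 log units; beyond the scatter), a modest loss, whereas both earlier replacements of the methyl were large losses. The entering and leaving groups have the same heavy-atom count and neither has hydrogen-bond donors or acceptors, yet the step lies beyond the scatter, so matching these counts does not keep the number unchanged. The compounds shown leave open how much of the step belongs to the bromine and how much to its place on the ring, and how a methoxy group or a chlorine would fare at this position. No evidence bearing on the cause of this step is available.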